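The source may hold more compounds than are shown below. What is called first, only, known or untested is meant among the compounds shown, and "the series" means these compounds.

In a functional assay on HT-29 cells (Homo sapiens) for cytotoxicity, read by sulforhodamine B assay (a lower number here means a stronger inhibitor, a higher number a weaker inhibitor), compound 1 (`C=C1[C@@H](OC(C)=O)C[C@@H]2[C@](C)(CO[Si](C)(C)C(C)(C)C)[C@H](OC(C)=O)CC[C@@]2(C)[C@@H]1C[C@@H](Nc1ccc(OC)c(OC)c1)C1=CCOC1=O`) gives 5330 nM as its reading. Going by the values given here, the only other measured member, compound 2 (`C=C1CC[C@@H]2[C@](C)(CO[Si](C)(C)C(C)(C)C)[C@H](OC(C)=O)CC[C@@]2(C)[C@@H]1C/C=C1/C(=O)OC[C@H]1OC(C)=O`), gives 4690 nM on the same read-out. These two numbers lie within the scatter of each other, so compound 1 holds no distinct place in this pair.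

Compound 3 (`C=C1[C@@H](OC(C)=O)C[C@@H]2[C@](C)(CO[Si](C)(C)C(C)(C)C)[C@H](OC(C)=O)CC[C@@]2(C)[C@@H]1C[C@@H](Nc1cccc(F)c1)C1=CCOC1=O`) keeps the core of compound 1 and carries 3-fluorophenyl in place of 3,4-dimethoxyphenyl on an amine nitrogen. Among the compounds with values here, no measured pair differs in one place only, so there is no step to carry over to this change. With nothing pointing either way, no step beyond the scatter is expected in this assay, and neither direction is favoured. The expected move (a 1.1-fold lower number from compound 1 to compound 3 (0.05 log units; within the scatter)) is accordingly small. Going by these compounds, the estimate rests on compound 1 at 5330 nM as its sole anchor, and the range is kept wide since this exchange is untested. For compound 3 the estimated value is 4800 nM with an expected range of 1800 nM to 12000 nM around it.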

Compound 3, half-maximal inhibitory concentration: 4520 nM
Estimate against measurement, compound 3: 1.1-fold (0.03 log units) above; measured number inside the range.
By their numbers in this assay, from the lowest: compounds 3, 2 and 1 (each within the scatter of the next).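

In this assay, going by these compounds alone, 3-fluorophenyl in place of 3,4-dimethoxyphenyl on the amine nitrogen gives a 1.2-fold lower number from compound 1 to compound 3 (0.07 log units; within the scatter), the only step so far that isolates a single place. This position therefore accepts an exchange of an aryl group carrying two methoxy groups for a smaller one carrying fluorine and no hydrogen-bond acceptors, with the reading remaining within the scatter of the parent. No measurement of any property of these two groups accompanies this result.

Going by these compounds, both groups on this nitrogen are substituted phenyl rings, so it remains open whether a non-aromatic group such as cyclohexyl or a longer alkyl chain, or a phenyl ring bearing a carboxylic acid, would leave the reading equally unchanged. On these data alone, the rest of the core is identical in compound 1 and compound 3, so it is also open whether replacing the silyl ether with a free hydroxyl would shift the reading.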